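Ring amine replacing pyridinylmethylamino on the shared core

The source may hold more compounds than are shown below. What is called first, only, known or untested is meant among the compounds shown, and "the series" means these compounds.

Measured compounds:
- compound 1, `CC(C(=O)NCc1ccc(C(F)(F)F)nc1NCc1cccnc1)c1ccc(NS(C)(=O)=O)c(F)c1`: "not active" (no number reported)
- compound 2, `C[C@@H](C(=O)NCc1ccc(C(F)(F)F)nc1N1CCC(c2ccccc2)CC1)c1ccc(NS(C)(=O)=O)c(F)c1`: 7.5 nM
- compound 3, `C[C@H](C(=O)NCc1ccc(C(F)(F)F)nc1N1CCC(c2ccccc2)CC1)c1ccc(NS(C)(=O)=O)c(F)c1`: 0.3 nM

In a functional assay on CHO-K1 cells for antagonist activity at transient receptor potential cation channel subfamily V member 1 (Homo sapiens), read by FLIPR (on this read-out higher numbers stand for weaker inhibition and lower numbers for stronger inhibition), compound 1 is reported as "not active" (no number reported), with no number given, so it stands apart from the two measured enantiomers without a quantified gap. Compounds 2 and 3 share the rest of the core with compound 1 but carry a different substituent at the site that is changed in compound 4; in this assay compound 2 gives 7.5 nM and compound 3 gives 0.3 nM. Going by the values given here, the only quantified step is a 25-fold lower number from compound 2 to compound 3 (1.40 log units; beyond the scatter), which rests on (the fact that compounds 2 and 3 differ only in the configuration as drawn).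

Compound 4, `CC(C(=O)NCc1ccc(C(F)(F)F)nc1N1CCCCCCC1)c1ccc(NS(C)(=O)=O)c(F)c1`, is compound 1 with the change (a group of 8 heavy atoms (7 carbon, 1 nitrogen; one eight-membered non-aromatic ring with 1 hetero atom) in place of a group of 8 heavy atoms (6 carbon, 2 nitrogen; one six-membered aromatic ring with 1 hetero atom), on an aromatic carbon). Among the compounds with values here, no measured step tracks this exact change, so no directional step size can be derived; the comparison is only that compound 1 is inactive while compounds 2 and 3, altered at the same aromatic carbon, are potent. Compound 4 is drawn without defined configuration, like compound 1.

On that basis compound 4 is expected to show activity in this assay, estimated at 40 nM. The plausible range for compound 4 is estimated to run from 3 nM to 500 nM.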

Compound 4, inhibition constant: 0.7 nM
Beside the measured number, compound 4's estimate is 57-fold (1.76 log units) above it; measured number below the stated range.
By their numbers in this assay, from the lowest: compound 3; then compound 4; then compound 2.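

Going by these compounds alone, compound 1 stands as "not active" (no number reported), so no step from it to compound 4 at 0.7 nM can be read. The compounds shown leave open how the two configurations of compound 4 would compare with each other. Nothing at hand bears on why compound 4 gives its value.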